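The source may report more compounds than this note shows. Statements on the series, on what has been measured and on what is new or still open speak of the compounds shown alone.

Working notes on the series. Compound 1 `COc1ccc(OC)c(Nc2cc(Nc3ccc(F)cc3)ncn2)c1` is measured in a functional assay on NCI-H1975 cells (Homo sapiens) for antiproliferative activity, read by MTT assay, with a stated time of 72 h (a lower number here means a stronger inhibitor, a higher number a weaker inhibitor), where compound 1 gives > 30000 nM, which is a limit of the assay rather than a number. Compound 2 `O=C(O)CCC(=O)Nc1cc(Nc2ccc(Cl)cc2)ncn1` gives 2730 nM in this assay. Compound 3 `Clc1ccc(Nc2cc(Nc3cccc(Cl)n3)ncn2)cc1` gives > 30000 nM in this assay, again a limit of the assay. Among the compounds with values here, the one measured step, an at least 10-fold higher number from compound 2 to compound 3 (1.04 log units; beyond the scatter), alters a different position of the shared core and does not touch the change now in question. Compound 4 `COc1cccc(Nc2cc(Nc3cc(OC)ccc3OC)ncn2)c1` differs from compound 1 by 3-methoxyphenyl in place of 4-fluorophenyl on a nitrogen on an aromatic ring. Within the data shown here, no measured step bears on this change; the nearest guidance is the limit of > 30000 nM in this assay, at which 2 of the 3 values shown sit. In view of the limit of > 30000 nM in this assay, at which 2 of the 3 values shown sit, compound 4 is expected to stay near that limit, with an estimated 30000 nM (range 10000 nM to 100000 nM), meaning an expected step of a number no higher from compound 1 to compound 4 (the limit leaves the size open).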

Compound 4, half-maximal inhibitory concentration: 890 nM
For compound 4 the middle estimate is 34-fold (1.53 log units) above the measured one; the measured number lies below the stated range.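

Placing 3-methoxyphenyl in place of 4-fluorophenyl on a nitrogen on an aromatic ring gives an at least 33-fold lower number from compound 1 to compound 4 (1.52 log units; beyond the scatter) in this assay, so this position responds to the group it carries. Compound 1 gives > 30000 nM, a limit of the assay, so this step fixes only a minimum size. Compound 4 therefore stands clear of the value at which other compounds sit: the limit of > 30000 nM in this assay, at which 2 of the 4 values shown sit.

The compounds shown do not separate the gain of methoxy from the loss of fluorine. As far as these compounds go, how an amine or a longer ether chain would read at this place remains open.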